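The source may report more compounds than this note shows. Statements on the series, on what has been measured and on what is new or still open speak of the compounds shown alone.

Measured in a functional assay on MCF7 cells (Homo sapiens) for antiproliferative activity, read by MTT assay; on this read-out lower numbers stand for stronger inhibition and higher numbers for weaker inhibition:

Compound 1 `CCCC/C=C\CCCCCCCCCc1cc(=O)c2c(O)cc(O)c(C)c2o1`: 17500 nM
Compound 2 `CCCC/C=C\CCCCCCCCCc1cc(=O)c2c(O)cc(OCOC)cc2o1`: > 67200 nM
Compound 3 `CCCC/C=C\CCCCCCCCCc1cc(=O)c2c(O)c(C)c(OCOC)c(C)c2o1`: > 67200 nM

Only compound 1 gives a true number here. The reading for compound 2 is a limit of the assay, not a number. The reading for compound 3 is also a limit, so compound 3 stands at the limit of > 67200 nM in this assay, at which 2 of the 3 values shown sit.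

The next compound is compound 4 `CCCC/C=C\CCCCCCCCCc1cc(=O)c2c(O)cc(OCOC)c(C)c2o1`. It is made from compound 3 by one small edit: hydrogen in place of methyl on an aromatic carbon. In words, hydrogen takes the place of methyl on an aromatic carbon, and the methoxymethoxy group stays.

For the measured compounds named here, no measured pair of compounds shows the effect of this edit on its own, so the expectation has to rest on close neighbours. Compound 4 keeps the methoxymethoxy group of compound 2, whose reading of > 67200 nM is likewise a limit. Compound 3 carries that group too. On this basis, no change beyond the usual scatter is expected in this assay, and a reading that is again only a limit is the likeliest outcome.

The estimated step that the limit leaves unreadable from compound 3 to compound 4 is expected to stay within that scatter. For compound 4 the expected value is 70000 nM, with an estimated range of 30000 nM to 130000 nM.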

Compound 4, half-maximal inhibitory concentration: > 67200 nM
Compound 4: a limit, no number; the forecaster's own chance of this, stated with the estimate: 70%; the middle value is on the limit's open side.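

In this assay, for the compounds shown here, the new result gives the first readable step between two compounds that differ in one place: methoxymethyl in place of hydrogen on an oxygen on an aromatic ring brings an at least 3.8-fold higher number from compound 1 to compound 4 (0.58 log units; beyond the scatter) with the methyl group on the neighbouring ring position unchanged in this pair. This ties the loss of a measurable value to that one oxygen, since the free hydroxy group of compound 1 gives a true number and the methoxymethoxy group of compound 4 gives only a limit. The steps that add or remove the methyl group on the aromatic carbon cannot be read because both ends of each are limits, so the methyl change has no visible size while the methoxymethoxy group stays: the limit of > 67200 nM in this assay, at which 3 of the 4 values shown sit.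

Going by these compounds, whether that methyl group matters once the hydroxy group is free stays open, since only compound 1 gives a number. Also open, on these data alone, is how a plain methoxy group or an amine at that same place would compare with the hydroxy group of compound 1.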